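The source may hold more compounds than are shown below. What is called first, only, known or untested is meant among the compounds shown, and "the series" means these compounds.

Measured in an ADME assay on CHO cells (Cricetulus griseus) for cytotoxicity, read by MTT assay; a lower number here means that less compound is tolerated, a higher number that more compound is tolerated:
- compound 1 `Fc1ccc(Nc2cc3[nH]c(Nc4ccc(C5CCNCC5)cn4)nc3cn2)cc1F`: 50000 nM
- compound 2 `O=C(c1ccnc(Nc2nc3cnc(Nc4ccc(F)c(C(F)(F)F)c4)cc3[nH]2)c1)N1CCN(C2CC2)CC1`: 30000 nM
- compound 3 `O=C(c1ccnc(Nc2nc3cnc(Nc4ccc(F)c(F)c4)cc3[nH]2)c1)N1CCN(C2CC2)CC1`: > 50000 nM, a limit and not a number

Compound 3 has no exact value in this assay. It stands at the limit of > 50000 nM in this assay, at which 1 of the 3 values shown sits. Compound 1 and compound 2 lie within the scatter of each other, so the two numbered values give no order.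

Compound 4 `O=C(c1ccnc(Nc2nc3cnc(Nc4ccc(F)c(F)c4)cc3[nH]2)c1)N1CCC(F)(F)CC1` carries 4,4-difluoropiperidin-1-yl in place of 4-cyclopropylpiperazin-1-yl on a carbonyl carbon. Among the measured compounds shown here, no measured step covers a change at this place. For the measured compounds named here, the only measured step is an at least 1.6-fold higher number from compound 2 to compound 3 (0.22 log units; that floor lies within the scatter), and it concerns fluoro in place of trifluoromethyl on an aromatic carbon, so it bears on the new change only indirectly. With that single step as the guide, no shift beyond the scatter is expected in this assay, and a drop in the number cannot be ruled out. The expected change is an at least 1.1-fold lower number from compound 3 to compound 4 (0.04 log units; that floor lies within the scatter). A result reported only as a limit is also expected to be about as likely as a number. For compound 4 the estimate is 45000 nM, with an expected range from 15000 nM to 50000 nM.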

Compound 4, half-maximal cytotoxic concentration in the CHO assay: 29000 nM
Beside the measured number, compound 4's estimate is 1.6-fold (0.19 log units) above it; the measured number falls inside the stated range.
By their numbers in the CHO assay, from the lowest: compounds 4, 2 and 1 (each within the scatter of the next).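

The carbonyl carbon now has its first measured change, 4,4-difluoropiperidin-1-yl in place of 4-cyclopropylpiperazin-1-yl, and in the CHO assay the result is an at least 1.7-fold lower number from compound 3 to compound 4 (0.23 log units; that floor lies within the scatter). In the CHO assay compound 3 gives > 50000 nM, a limit and not a number, so this step has only a floor, and that floor neither establishes nor excludes a change beyond the scatter. In the CHO assay compound 4 gives 29000 nM, which adds an exact number at this position.

In a physicochemical assay for solubility, read by HPLC, using the shake flask method, in phosphate buffer, measured as kinetic solubility, with a stated time of 20 h, at pH 6.5 (on this read-out lower numbers stand for lower solubility and higher numbers for higher solubility), compound 3 gives < 5000 nM, a limit and not a number. In the physicochemical assay compound 4 gives < 5000 nM, also a limit and not a number. In the physicochemical assay the step from compound 3 to compound 4 cannot be read, as both compounds sit at the same limit: the limit of < 5000 nM in the physicochemical assay, at which 2 of the 2 values shown sit.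
Still open, from the compounds shown here alone, is where a morpholine amide or a dimethylamine amide on this carbonyl carbon would fall in the CHO assay, and whether any amide at this position would give a number rather than a limit in the physicochemical assay.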